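The source may report more compounds than this note shows. Statements on the series, on what has been measured and on what is new or still open speak of the compounds shown alone.

Working notes on the series. Compound 1 `C#CCOC(=O)C[C@@H]1C(C(=O)OC)=CO[C@@H](O[C@@H]2O[C@H](CO)[C@@H](O)[C@H](O)[C@H]2O)/C1=C/C` is read in a functional assay on SK-BR-3 cells (Homo sapiens) for antiproliferative activity, read by MTT assay, with a stated time of 72 h; on this read-out lower numbers stand for stronger inhibition and higher numbers for weaker inhibition. In this assay compound 1 returns only a limit, > 15000 nM. Compound 2 `C/C=C1/[C@H](O[C@@H]2O[C@H](COC(C)=O)[C@@H](OC(C)=O)[C@H](OC(C)=O)[C@H]2OC(C)=O)OC=C(C(=O)O)[C@H]1CC(=O)OC` is also read in this assay, and for compound 2 the result is likewise a limit, > 20000 nM. Both results shown are limits, one at the limit of > 15000 nM in this assay, at which 1 of the 2 values shown sits, and one at the limit of > 20000 nM in this assay, at which 1 of the 2 values shown sits, so compound 1 stands at a limit with no measured neighbour that would define a step. Compound 3 `C/C=C1/[C@H](O[C@@H]2O[C@H](CO)[C@@H](O)[C@H](O)[C@H]2O)OC=C(C(=O)OC)[C@H]1CC(=O)O` has not yet been measured. It differs from compound 1 by hydrogen in place of propargyl on an oxygen next to a carbonyl group. Going by the values given here, no step between measured compounds is recorded, so the size of the change in this assay is open; nothing beyond the usual scatter is expected, and the result is likely to come back as a limit again. For compound 3 the estimate is 20000 nM, in the range 8000 nM to 50000 nM. The expected step that the limit leaves unreadable from compound 1 to compound 3 is small.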

Compound 3, half-maximal inhibitory concentration: > 15000 nM
Compound 3: only a limit was reported (the forecaster's own chance of this, stated with the estimate: 75%); the middle value does not contradict the limit.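

Going by these compounds alone, compound 1 and compound 3 both return only limits in this assay, so no step between them can be read. The compounds shown leave open whether hydrogen in place of propargyl on an oxygen next to a carbonyl group changes the read-out at all.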